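The source may hold more compounds than are shown below. What is called first, only, known or untested is meant among the compounds shown, and "the series" means these compounds.

Of the compounds shown here, three built on a shared core have been measured in a functional assay on MCF7 cells (Homo sapiens) for inhibition, read by sulforhodamine B assay, with a stated time of 72 h; a higher number here means a weaker inhibitor, a lower number a stronger inhibitor. Compound 1 `Cc1ccc(C2=Nn3c(nnc3C(C)c3ccc(CC(C)C)cc3)SC2)cc1` gives 6300 nM. Compound 2 `CC(C)Cc1ccc(C(C)c2nnc3n2N=C(c2ccc(Cl)cc2)CS3)cc1` gives 8800 nM. Compound 3 `CC(c1ccc(-c2ccccc2)c(F)c1)c1nnc2n1N=C(c1ccccc1)CS2` gives 7400 nM. Among the measured compounds shown here, the only pair that differs in a single place gives the step of a 1.4-fold higher number from compound 1 to compound 2 (0.15 log units; within the scatter), a chloro in place of methyl on an aromatic carbon. Compound 3 therefore stands second highest of the three numbers, with compound 1 its nearest neighbour and compound 2 its furthest, and both gaps lie within the scatter, so nothing separates the three.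

Compound 4 `Cc1ccc(C2=Nn3c(nnc3C(C)c3ccc(-c4ccccc4)c(F)c3)SC2)cc1` differs from compound 3 by methyl in place of hydrogen on an aromatic carbon. For the measured compounds named here, no measured pair shows a methyl gained from hydrogen; the step from compound 1 to compound 2 is the closest comparison, an exchange of one group for another at the place where compound 4 carries its methyl, and it stayed within the scatter. On that basis the expected step is a 1.1-fold lower number from compound 3 to compound 4 (0.02 log units; within the scatter), none beyond the scatter. Compound 4 is thus estimated at 7000 nM in this assay, with a range from 3500 nM to 14000 nM.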

Compound 4, half-maximal inhibitory concentration: 5000 nM
Estimate against measurement, compound 4: 1.4-fold (0.15 log units) above, within the range that was stated.
By their numbers in this assay, from the lowest: compounds 4, 1, 3 and 2 (each within the scatter of the next).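

In this assay, the change from phenyl to 4-methylphenyl, on an aromatic carbon para to a large group, gives a 1.5-fold lower number from compound 3 to compound 4 (0.17 log units; within the scatter). Among the compounds shown here, this is the first direct reading of a methyl gained from hydrogen at this place, and, like a 1.4-fold higher number from compound 1 to compound 2 (0.15 log units; within the scatter), it stays within the scatter, so neither of the two single changes read here separates its pair of compounds, although the two pairs differ in the rest of the molecule. The position has therefore tolerated a methyl in place of hydrogen and a chloro in place of methyl without a measurable shift in either pair, but no independent measurement bears on why the numbers stay so close.

From the compounds shown here alone, what remains open is whether any group at this aromatic carbon can move the number beyond the scatter, for instance a methoxy group, an amine, a carboxylic acid or a longer chain such as butyl. The compounds shown also leave open whether a methyl gained from hydrogen would behave in the same way with the rest of the molecule changed.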